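A Larger Ring on the Carbonyl Side Chain

The source may report more compounds than this note shows. Statements on the series, on what has been measured and on what is new or still open speak of the compounds shown alone.

Measured compounds:
compound 1, `Cc1c(OCCCCOc2ccc(C(=O)O)c(Cl)c2)ccc(C(=O)CC(C)C)c1O`, 2050 nM
compound 2, `Cc1c(OCCCCOc2cccc(C(=O)O)c2)ccc(C(=O)CC(C)C)c1O`, 1430 nM
compound 3, `COc1ccc(C(=O)O)cc1OCCCCOc1ccc(C(=O)C(C)C)c(O)c1C`, 588 nM

All three were tested in an assay on HEK293 cells for positive allosteric modulation of metabotropic glutamate receptor 3 (Rattus norvegicus), read by thallium flux, with a stated time of 2.5 min; a lower number here means that less compound is needed, a higher number that more compound is needed for the effect. Compound 1 has the highest number of the three. Its nearest neighbour is compound 2, reached by a 1.4-fold lower number from compound 1 to compound 2 (0.16 log units; within the scatter), a change on the aryl carboxylic acid end of the molecule. For the measured compounds named here, compound 3 stands furthest away: compound 3 gives 588 nM, beyond the scatter from compound 1, but it differs from compound 1 in more than one place, so no single step is drawn between them.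

The unmeasured compound 4, `Cc1c(OCCCCOc2ccc(C(=O)O)c(Cl)c2)ccc(C(=O)CC2CCCC2)c1O`, differs from compound 1 only by cyclopentyl in place of isopropyl on a saturated chain carbon bound to a carbonyl carbon. Going by the values given here, no measured step touches this part of the molecule: the one step in hand, a 1.4-fold lower number from compound 1 to compound 2 (0.16 log units; within the scatter), alters the aryl acid and was itself within the scatter. With nothing to point either way, compound 4 is expected to land close to compound 1, and the step of a 1.3-fold lower number from compound 1 to compound 4 (0.11 log units; within the scatter) is estimated to stay within the scatter. The estimate for compound 4 is 1600 nM, with a range from 500 nM to 5000 nM.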

Compound 4, half-maximal effective concentration: 2250 nM
Beside the measured number, compound 4's estimate is 1.4-fold (0.15 log units) below it; measured number inside the range.
By their numbers in this assay, from the lowest: compound 3; then compounds 2, 1 and 4 (each within the scatter of the next).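

Swapping isopropyl for cyclopentyl, on a saturated chain carbon bound to a carbonyl carbon, replaces a group of 3 heavy atoms and no ring with one of 5 heavy atoms and a five-membered ring of carbon only. This gives a 1.1-fold higher number from compound 1 to compound 4 (0.04 log units; within the scatter), the only step shown at this end of the molecule. At this place, then, the ring and the added carbons leave the number within the scatter of the isopropyl compound, and the two groups cannot be told apart here. No outside evidence bears on this result.

Still open, from the compounds shown here alone, is whether a ring of another size, such as cyclohexyl, or a flat aromatic ring such as phenyl, would read the same here. Also open, going by these compounds, is whether a group carrying nitrogen or oxygen, such as an amine or a hydroxyl, would move the number at this place.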